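The source may report more compounds than this note shows. Statements on the series, on what has been measured and on what is new or still open speak of the compounds shown alone.

Measured so far in an assay on HEK293 cells for displacement of a labelled ligand from adenosine receptor A2b (Homo sapiens), read by scintillation counting, with a stated time of 30 min, tested at 10 uM; on this read-out higher numbers stand for more inhibition at the one concentration tested (going by the name of the read-out) and lower numbers for less inhibition:
- compound 1 `N=c1oc2ccc(Br)cc2cc1C(=O)NCC(O)CO` gives 4%
- compound 2 `O=C(NC1CCCC1)c1cc2ccccc2oc1=O` gives 18%
- compound 3 `COc1cccc2cc(C(=O)NCCO)c(=N)oc12` gives 65%

Compound 1 stands lowest of the three numbers. Its nearest neighbour is compound 2, whose reading lies above it by a gap beyond the scatter; compound 3 lies furthest above it, again beyond the scatter. Among the measured compounds shown here, no two of the measured compounds differ in a single place, so no measured step is available.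

Compound 4 `N=c1oc2ccc(Br)cc2cc1C(=O)NC1CCCCC1` keeps the core of compound 1 and changes only the amide substituent: cyclohexyl in place of 2,3-dihydroxypropyl on an amide-type nitrogen. Among the measured compounds, compound 2 is the only one carrying a carbocyclic amide substituent, and in this assay compound 2 gives 18%, which sits above compound 1 but on a different core, so it is a weak guide only.

The step is expected to be upward and of modest size, a number 16 percentage points higher from compound 1 to compound 4 (beyond the scatter), plausibly just beyond the scatter but not certainly so. For compound 4 the estimated inhibition is 20%, within a range of 0% to 50%.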

Compound 4, a percentage reported as inhibition, at one concentration (the size of the read-out at that concentration, not a potency): 10%
Beside the measured number, compound 4's estimate is 10 percentage points above it; the measured number falls inside the stated range.
By their numbers in this assay, from the lowest: compounds 1, 4 and 2 (each within the scatter of the next, the first and the last beyond it); then compound 3.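

Among the compounds shown here, the first single-place comparison, made on an amide-type nitrogen, reads a number 6 percentage points higher from compound 1 to compound 4 (within the scatter) in this assay and puts cyclohexyl and 2,3-dihydroxypropyl on the same footing within the scatter. On the core of compound 1, a ring of carbon only with no hydrogen-bond donors or acceptors therefore cannot be told apart from an open chain that carries both. No measurement bearing on the reason for this is available.

Still open, as far as these compounds go, is whether any substituent at this nitrogen can separate itself from these two readings, for example an aminoethyl chain, a carboxymethyl group bearing a carboxylic acid, or a longer alkyl chain. Equally open, from the compounds shown here alone, is whether the same exchange would read alike on any other core.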